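A three-membered ring enters at the amide nitrogen

The source may hold more compounds than are shown below. What is called first, only, known or untested is meant among the compounds shown, and "the series" means these compounds.

Among the compounds with values here, in an assay on isolated protein for inhibition of histone deacetylase 4 (Homo sapiens), read by fluorescence (on this read-out higher numbers stand for weaker inhibition and lower numbers for stronger inhibition), compound 3 `CC(C)(CN1CCCC1)NC(=O)c1ccc(-c2noc(C(F)(F)F)n2)cc1` gives 280 nM, the second highest of the three numbers so far. Compound 1 `C[C@H](CN1CCC(F)CC1)NC(=O)c1ccc(-c2noc(C(F)(F)F)n2)cc1` gives 30 nM and compound 2 `CCCN(CCC)C[C@@H](C)NC(=O)c1ccc(-c2nc(C(F)(F)F)no2)cc1` gives 28000 nM, and the gap from compound 3 to each of them lies beyond the scatter. Compound 4 `O=C(NC1(CN2CCCC2)CC1)c1ccc(-c2noc(C(F)(F)F)n2)cc1` has not yet been measured. It differs from compound 3 in one place: 1-((pyrrolidin-1-yl)methyl)cyclopropyl in place of 1-methyl-1-((pyrrolidin-1-yl)methyl)ethyl on an amide-type nitrogen. Within the data shown here, no measured pair shows this exchange, so nothing directly tells its size. Since the two groups match in what is counted under that difference, the step is expected to be a 1.1-fold lower number from compound 3 to compound 4 (0.05 log units; within the scatter), within the scatter and in no sure direction. Compound 4 is therefore estimated to give about 250 nM in this assay, between 80 nM and 800 nM.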

Compound 4, half-maximal inhibitory concentration: 40 nM
For compound 4 the middle estimate is 6.3-fold (0.80 log units) above the measured one, outside the stated range (below it).
By their numbers in this assay, from the lowest: compounds 1 and 4 (each within the scatter of the next); then compound 3; then compound 2.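

In this assay, the step of a 7.0-fold lower number from compound 3 to compound 4 (0.85 log units; beyond the scatter) comes with 1-((pyrrolidin-1-yl)methyl)cyclopropyl in place of 1-methyl-1-((pyrrolidin-1-yl)methyl)ethyl on an amide-type nitrogen. Within the data shown here, this position therefore responds to the exchange even though the two groups match in heavy atoms, hydrogen-bond donors and hydrogen-bond acceptors, which the earlier compounds could not show. Nothing measured here accounts for the size of this step. The compounds shown leave open whether a cyclobutyl ring in place of the cyclopropyl ring would keep this gain, and whether the gain would persist with a morpholine in place of the pyrrolidine.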